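The source may report more compounds than this note shows. Statements on the series, on what has been measured and on what is new or still open speak of the compounds shown alone.

Measured so far in a functional assay on A549 cells (Homo sapiens) for inhibition, read by sulforhodamine B assay, with a stated time of 72 h; on this read-out lower numbers stand for stronger inhibition of growth and higher numbers for weaker inhibition of growth:
- compound 1 `O=C(/C=C/c1ccncc1-c1ccc2ccccc2c1)NC1CC1` gives 5840 nM
- compound 2 `NNC(=O)CCc1ccncc1-c1ccc2ccccc2c1` is reported only as a limit, > 10000 nM
- compound 3 `CN1CCN(C(=O)/C=C/c2ccncc2-c2ccc3ccccc3c2)CC1` is reported only as a limit, > 10000 nM

Compound 3 thus stands at the limit of this assay; no number is known for it, only that it lies beyond what the assay reports (the limit of > 10000 nM in this assay, at which 2 of the 3 values shown sit). The next compound, compound 4 `CN(C)C(=O)/C=C/c1ccncc1-c1ccc2ccccc2c1`, differs from compound 3 in one place: dimethylamino in place of 4-methylpiperazin-1-yl on a carbonyl carbon. Going by the values given here, of the measured steps, the one from compound 1 to compound 3 bears most directly on this, since it also exchanges the group on the carbonyl carbon: an at least 1.7-fold higher number from compound 1 to compound 3 (0.23 log units; that floor lies within the scatter). The other step, an at least 1.7-fold higher number from compound 1 to compound 2 (0.23 log units; that floor lies within the scatter), alters a different part of the molecule and is only a weak guide. Among the compounds with values here, both measured steps run from a number to a limit, so neither sets a size beyond its floor, and no measured pair sets a size for the move to dimethylamino. Compound 4 is therefore expected to sit close to compound 3, the step of an at least 1.1-fold lower number from compound 3 to compound 4 (0.04 log units; that floor lies within the scatter) being expected to stay within the scatter. Compound 4 is estimated at 9000 nM, between 3000 nM and 25000 nM, with a fair chance that this assay again reports only its limit.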

Compound 4, concentration for 50% growth inhibition: 5800 nM
For compound 4 the middle estimate is 1.6-fold (0.19 log units) above the measured one; the measured number falls inside the stated range.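

Replacing 4-methylpiperazin-1-yl with dimethylamino on a carbonyl carbon gives a number in this assay where compound 3 gave only a limit, with an at least 1.7-fold lower number from compound 3 to compound 4 (0.23 log units; that floor lies within the scatter). Dimethylamino and cyclopropylamino on that carbonyl carbon cannot be told apart, with a 1.0-fold lower number from compound 1 to compound 4 (0.00 log units; within the scatter). Taking 2-(dimethylcarbamoyl)ethenyl in place of 2-(aminocarbamoyl)ethyl on an aromatic carbon gives an at least 1.7-fold lower number from compound 2 to compound 4 (0.23 log units; that floor lies within the scatter), and this too is only a floor, as compound 2 and compound 3 both remain limits: the limit of > 10000 nM in this assay, at which 2 of the 4 values shown sit.

From the compounds shown here alone, the true size of the steps from those two limits stays open. Also open, going by these compounds, is whether a morpholine, a primary amine or a longer alkyl chain on the carbonyl carbon, or a carboxylic acid in place of the amide, would shift the number beyond the scatter.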